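Amine substituent variation at the aromatic carbon

The compounds below may be only part of what the source reports. "The series", "measured", "known", "first", "only" and "open" are said of these compounds alone.

Measured so far in a functional assay on L02 cells (Homo sapiens) for inhibition, read by Griess assay, with stated times of 1 h and 24 h; on this read-out higher numbers stand for weaker inhibition and lower numbers for stronger inhibition:
compound 1 `CNc1nc(/C=C/c2cc(OC)c(OC)c(OC)c2)nc2ccsc12` gives > 1000000 nM;
compound 2 `CCN1CCN(c2nc(/C=C/c3cc(OC)c(OC)c(OC)c3)nc3ccsc23)CC1` gives > 1000000 nM;
compound 3 `COc1cc(/C=C/c2nc(Nc3ccc(C)cc3)c3sccc3n2)cc(OC)c1OC` gives < 40000 nM.

The value of compound 1 is a limit of this assay. The value of compound 2 is likewise a limit. The value of compound 3 is also a limit, not a number. Compound 3 thus sits at the limit of < 40000 nM in this assay, at which 1 of the 3 values shown sits, the lowest point shown, while compound 1 and compound 2 sit at the limit of > 1000000 nM in this assay, at which 2 of the 3 values shown sit. The steps of an at least 25-fold lower number from compound 1 to compound 3 (1.39 log units; beyond the scatter) and an at least 25-fold lower number from compound 2 to compound 3 (1.39 log units; beyond the scatter) were both large. Compound 4 `COc1cc(/C=C/c2nc(N(C)c3ccccc3)c3sccc3n2)cc(OC)c1OC` differs from compound 3 by methyl(phenyl)amino in place of (4-methylphenyl)amino on an aromatic carbon; the two have the same atoms, joined differently. Going by the values given here, no measured step tests such a rearrangement, so the measured steps give no direction, and the expected step that the limit leaves unreadable from compound 3 to compound 4 is small, within the scatter. Compound 4 is expected to give 30000 nM, range 5000 nM to 200000 nM, in this assay.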

Compound 4, half-maximal inhibitory concentration: 767000 nM
Estimate against measurement, compound 4: 26-fold (1.41 log units) below, and the stated range ends below it.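

The step of an at least 19-fold higher number from compound 3 to compound 4 (1.28 log units; beyond the scatter) is large, so at this position the result depends on how the atoms of the group are joined, not just on which atoms are present. The change swaps (4-methylphenyl)amino, with 1 hydrogen-bond donor, for methyl(phenyl)amino, with 0 hydrogen-bond donors. The steps of an at least 1.3-fold lower number from compound 2 to compound 4 (0.11 log units; that floor lies within the scatter) and an at least 1.3-fold lower number from compound 1 to compound 4 (0.11 log units; that floor lies within the scatter) have floors within the scatter, so neither sets compound 4 clearly apart from the other two amines.

As far as these compounds go, whether the methyl on nitrogen or the missing methyl on the ring drives the loss stays open. A phenylamino or methyl(4-methylphenyl)amino group on this carbon would separate the two.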